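This account rests on a few compounds, and the source may have more. Where it says the series, first, only, none or still open, it means among the compounds named here.

Working notes on the methoxyalkylamine series.

Compound 1 `COCCNC(=C\C(=O)/C=C/c1ccc(O)cc1)/C=C/c1ccc(O)cc1` is the parent of the first pair. In a functional assay on Caco-2 cells (Homo sapiens) for activation, read by fluorescence, tested at 1 uM (on this read-out lower numbers stand for a stronger effect and higher numbers for a weaker effect at the one concentration tested), compound 1 gives 94.9%. Compound 3 `COCCCNC(=C\C(=O)/C=C/c1ccc(O)cc1)/C=C/c1ccc(O)cc1` carries the change (methoxymethyl in place of methoxy on a saturated chain carbon, two bonds along the chain from an amine nitrogen); in this assay compound 3 gives 97%, which amounts to a number 2.1 percentage points higher from compound 1 to compound 3 (within the scatter).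

Compound 2 `COCCNC(=C\C(=O)/C=C/c1ccc(O)c(OC)c1)/C=C/c1ccc(O)c(OC)c1` sits on a second core; how the core of compound 2 differs from the core of compound 1 is not broken down here. In this assay compound 2 gives 105%. Set against compound 3 this value lies within the scatter, set against compound 1 it lies beyond it.

Compound 4 `COCCCNC(=C\C(=O)/C=C/c1ccc(O)c(OC)c1)/C=C/c1ccc(O)c(OC)c1` is the unmeasured partner of compound 2, obtained through the change (methoxymethyl in place of methoxy on a saturated chain carbon, two bonds along the chain from an amine nitrogen), placed as in the first pair. The place is the same in both pairs, so the change counts as the same one, seen twice among these four compounds and measured only once so far, where it stayed within the scatter.

Within the data shown here, the expected step in this assay is a number 2 percentage points higher from compound 2 to compound 4 (within the scatter) because the one measured instance gave a number 2.1 percentage points higher from compound 1 to compound 3 (within the scatter). Among the measured compounds shown here, nothing in the data points to the second core answering this change differently, but only one precedent exists, so the range is kept wide. For compound 4 in this assay the expected value is 107%, with a plausible range from 97% to 117%.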

Compound 4, a percentage reported as activity, at one concentration (the size of the read-out at that concentration, not a potency): 97.9%
Estimate against measurement, compound 4: 9.1 percentage points above; the range from low to high includes it.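

On the second core, the change from methoxy to methoxymethyl on the saturated chain carbon gives, in this assay, a number 7.1 percentage points lower from compound 2 to compound 4 (within the scatter). Set beside the first pair, the two steps do not separate, so the series gives no sign that the core of compound 2 and the core of compound 1 answer this change differently: the same change on two cores in this assay, a number 2.1 percentage points higher (within the scatter) from compound 1 to compound 3 and a number 7.1 percentage points lower (within the scatter) from compound 2 to compound 4, 9.2 percentage points apart, within the scatter of two such steps. Among these compounds, this supports carrying the change from one of these cores to the other with no difference beyond the scatter, but it does not show that the two cores answer identically, since a small difference could lie hidden in the scatter, and with only two pairs, each read at a single concentration, it gives no potency and no rule for any other core.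

The compounds shown leave open whether a longer methoxyalkyl chain would give a step beyond the scatter on either core, and whether a terminal amine or a carboxylic acid in place of the methoxy group would do so. Also open, on these data alone, is whether the same change, carried onto a core with other substituents on its aromatic rings, would stay within the scatter.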